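The source may report more compounds than this note shows. Statements on the series, on what has been measured and on what is new or still open speak of the compounds shown alone.

Measured in a functional assay on MT4 cells (Homo sapiens) for cytotoxicity; on this read-out lower numbers stand for stronger inhibition and higher numbers for weaker inhibition:
- Compound 1 `N#Cc1c(N)cccc1Sc1cccc(Cl)c1`: 53000 nM
- Compound 2 `Cc1cc(C)cc(Sc2cccc(N)c2C#N)c1`: > 2000 nM (a limit of the assay, not a number)
- Compound 3 `N#Cc1c(N)cccc1Sc1cc(Cl)cc(Cl)c1`: 3000 nM

Compound 3 holds the lower of the two exact numbers, well under compound 1. Compound 4 `Cc1cc(Cl)cc(Sc2cccc(N)c2C#N)c1` has methyl in place of chloro on an aromatic carbon of compound 3 (methyl in place of chloro on an aromatic carbon). Going by the values given here, no measured step makes this swap. The nearest guide is the large step with chloro in place of hydrogen (an 18-fold lower number from compound 1 to compound 3 (1.25 log units; beyond the scatter)). Here that carbon keeps a group instead of returning to hydrogen, so only part of that step should be lost. In this assay the expected step is small and toward a higher number, probably within the scatter (a 1.7-fold higher number from compound 3 to compound 4 (0.22 log units; within the scatter)). Compound 4 is estimated at 5000 nM, with an expected range from 1500 nM to 20000 nM.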

Compound 4, half-maximal inhibitory concentration: 16000 nM
The estimate for compound 4 lay 3.2-fold (0.51 log units) below the measured number; the range from low to high includes it.
By their numbers in this assay, from the lowest: compound 3; then compound 4; then compound 1.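

In this assay this position now shows a graded result rather than a simple on-or-off effect. Replacing chloro with methyl gives a 5.3-fold higher number from compound 3 to compound 4 (0.73 log units; beyond the scatter) beyond the scatter, so the two groups are not interchangeable here. Methyl still gives a 3.3-fold lower number from compound 1 to compound 4 (0.52 log units; beyond the scatter) and so keeps part of the drop seen with chloro, placing it between hydrogen and chloro on this read-out.

The step between compound 2 and compound 4 cannot be read, because compound 2 gives only a limit: the limit of > 2000 nM in this assay, at which 1 of the 4 values shown sits. As far as these compounds go, whether bromo, methoxy or an amine at this position would fit the same order remains open.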